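A few compounds are considered here, and "the series" means these few. Any claim that something is new, unique, unknown or untested is made for them only; others in the source may bear on it.

Compound 3 `N#CC1=C(N)Oc2c(c3nc4ccccc4nc3c3ccccc23)C12C(=O)N(Cc1cnnn1-c1ccc(N)cc1)c1ccccc12` carries a 4-aminophenyl on an aromatic nitrogen of a five-membered aromatic ring with 3 nitrogen. In an ADME assay on L02 cells (Homo sapiens) for antiproliferative activity, read by MTT assay, with a stated time of 48 h (a higher number here means a weaker inhibitor, a lower number a stronger inhibitor), compound 3 reaches only a limit, > 50000 nM. Compound 1 `N#CC1=C(N)Oc2c(c3nc4ccccc4nc3c3ccccc23)C12C(=O)N(Cc1cnnn1-c1ccc(Br)cc1)c1ccccc12` bears a 4-bromophenyl on the same aromatic nitrogen; in this assay compound 1 likewise stops at a limit, > 50000 nM. Compound 2 `N#CC1=C(N)Oc2c(c3nc4ccccc4nc3c3ccccc23)C12C(=O)N(Cc1cnnn1-c1ccccc1Br)c1ccccc12` carries a 2-bromophenyl there, and in this assay compound 2 gives the limit > 50000 nM. Compound 3 therefore stands exactly where every measured value stands: the limit of > 50000 nM in this assay, at which 3 of the 3 values shown sit. The steps a step that the two limits leave unreadable from compound 1 to compound 2, a step that the two limits leave unreadable from compound 1 to compound 3 and a step that the two limits leave unreadable from compound 2 to compound 3 cannot be sized; each runs between two limits. Compound 4 `N#CC1=C(N)Oc2c(c3nc4ccccc4nc3c3ccccc23)C12C(=O)N(Cc1cnnn1-c1cccc(S(N)(=O)=O)c1)c1ccccc12` brings the next change: 3-sulfamoylphenyl in place of 4-aminophenyl on an aromatic nitrogen. Among the measured compounds shown here, no measured step offers a readable size or direction for this change, so compound 4 is expected to remain at the limit as well. The estimate for compound 4 in this assay is 80000 nM, with a range from 30000 nM to 300000 nM. This corresponds to an expected step that the limit leaves unreadable from compound 3 to compound 4, which is not expected to rise above the scatter.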

Compound 4, half-maximal inhibitory concentration: > 50000 nM
Compound 4 was reported as a limit; the forecaster's own chance of this, stated with the estimate: 85%; the middle value does not contradict the limit.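

Among the compounds shown here, compound 4 is reported only as a limit in this assay, like compound 1, compound 2 and compound 3, so no step from any of them to compound 4 can be read: the limit of > 50000 nM in this assay, at which 4 of the 4 values shown sit. The compounds shown leave open whether any group on that aromatic nitrogen would give a readable value in this assay.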